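The compounds below may be only part of what the source reports. "The series", "measured", "known", "first", "only" and "open" are said of these compounds alone.

Compound 3 `COc1cc(N(C)C(=O)c2ccccc2)cc(OC)c1OC` and compound 1 `COc1cc(N(C)C(=O)c2cccc([N+](=O)[O-])c2)cc(OC)c1OC` share one core and differ by a single change, (nitro in place of hydrogen on an aromatic carbon). In a functional assay on Daoy cells (Homo sapiens) for cytotoxicity, read by MTT assay, with a stated time of 72 h (a lower number here means a stronger inhibitor, a higher number a weaker inhibitor), compound 3 gives >= 125000 nM, which is a limit of the assay rather than a number. In this assay compound 1 likewise gives >= 125000 nM, again a limit. The step that the two limits leave unreadable from compound 3 to compound 1 therefore cannot be sized, since both values sit at the limit of >= 125000 nM in this assay, at which 2 of the 3 values shown sit. Compound 2 `COc1cc(NC(=O)Nc2ccccc2)cc(OC)c1OC` rests on another core; the difference between the two cores is not broken down here. In this assay compound 2 has "not determined" (no result reported). Compound 4 `COc1cc(NC(=O)Nc2cccc([N+](=O)[O-])c2)cc(OC)c1OC` arises from compound 2 by the same kind of change, (nitro in place of hydrogen on an aromatic carbon), and the place of the change reads the same in both pairs. With no readable step to lean on, compound 4 is expected to give about 150000 nM in this assay, most probably as a limit once more.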

Compound 4, half-maximal inhibitory concentration: 82500 nM
For compound 4 the middle estimate is 1.8-fold (0.26 log units) above the measured one, and the stated range covers the measured number.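

Compound 2 has no number to set against compound 4, so no new step can be read from this pair. From the compounds shown here alone, how nitro in place of hydrogen shifts the values in this assay remains open on both cores.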